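The source may hold more compounds than are shown below. What is called first, only, known or untested is meant among the compounds shown, and "the series" means these compounds.

Of the compounds shown here, two have been measured so far. Compound 1 `COc1ccc(C2CC(c3cccc([N+](=O)[O-])c3)=NN2C(C)=O)cc1` gives 7830 nM in a functional assay on PC-3 cells (Homo sapiens) for cytotoxicity, read by sulforhodamine B assay, with a stated time of 48 h; on this read-out lower numbers stand for stronger inhibition and higher numbers for weaker inhibition. Compound 2 `O=CCN1N=C(c2ccc3ccccc3c2)CC1c1cccc([N+](=O)[O-])c1` gives 2980 nM in this assay, the lowest of the two numbers, and its gap to compound 1 lies beyond the usual scatter of repeated measurements. Compound 3 `O=CCN1N=C(c2ccc3ccccc3c2)CC1c1ccco1` has not been measured yet. It differs from compound 2 in one place: furan-2-yl in place of 3-nitrophenyl on a saturated ring carbon. For the measured compounds named here, no pair of measured compounds that differ in just this place is available, so the size of the change in this assay can only be guessed; a moderate rise in the number, toward weaker inhibition, seems somewhat more likely than a fall, though a shift within the scatter cannot be ruled out. For compound 3 the expected value in this assay is 6000 nM, with a range from 2000 nM to 18000 nM. That estimate corresponds to an expected step of a 2.0-fold higher number from compound 2 to compound 3 (0.30 log units; within the scatter).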

Compound 3, half-maximal inhibitory concentration: 23000 nM
Compound 3: the middle estimate sits 3.8-fold (0.58 log units) below what was measured; measured number outside the range, above it.
By their numbers in this assay, from the lowest: compound 2; then compound 1; then compound 3.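

For the compounds shown here, this is the first pair of compounds that differ only in the group on the saturated ring carbon, so it isolates the effect of that position. In this assay, furan-2-yl in place of 3-nitrophenyl gives a 7.7-fold higher number from compound 2 to compound 3 (0.89 log units; beyond the scatter), a change beyond the scatter toward weaker inhibition, which shows that the group at this position strongly affects the result and that this assay favours 3-nitrophenyl over furan-2-yl. No measurement at hand gives a reason for this rise.

From the compounds shown here alone, it remains open which part of 3-nitrophenyl matters, since a plain phenyl or a 3-aminophenyl on this carbon would separate the nitro group from the ring carrying it. Going by these compounds, it is also open whether the same swap would have a similar effect with a longer chain in place of the formylmethyl group.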